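Swapping 4-hydroxy-2-methylphenyl for 4-ethylphenyl

This account rests on a few compounds, and the source may have more. Where it says the series, first, only, none or still open, it means among the compounds named here.

Compound 1 `Cc1ccc(C2=NN(c3ccc(S(C)(=O)=O)cc3)C(=O)CC2)cc1` gives 380 nM
Compound 2 `Cc1cc(O)ccc1C1=NN(c2ccc(S(C)(=O)=O)cc2)C(=O)CC1` gives 3850 nM

In a functional assay on M14 cells (Homo sapiens) for inhibition, read by sulforhodamine B assay, with a stated time of 48 h (a lower number here means a stronger inhibitor of growth, a higher number a weaker inhibitor of growth), compound 2 stands at 3850 nM as the higher of the two numbers, which makes it the weaker inhibitor of growth. Compound 3 `CCc1ccc(C2=NN(c3ccc(S(C)(=O)=O)cc3)C(=O)CC2)cc1` has not yet been measured. It carries 4-ethylphenyl in place of 4-hydroxy-2-methylphenyl on a carbon with a double bond to nitrogen and keeps the rest of the core of compound 2 unchanged.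

Going by the values given here, one measured step bears on this change, and it is large: a 10-fold higher number from compound 1 to compound 2 (1.01 log units; beyond the scatter) with 4-hydroxy-2-methylphenyl in place of 4-methylphenyl at the same place. Compound 3 leaves that same group again, so a large step of similar size toward a lower number is expected in this assay on this single precedent. The estimated step is an 8.6-fold lower number from compound 2 to compound 3 (0.93 log units; beyond the scatter) as expected from that reasoning. The value expected for compound 3 is 450 nM within an estimated range from 150 nM to 1300 nM in this assay.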

Compound 3, concentration for 50% growth inhibition: 630 nM
Compound 3: middle estimate off by 1.4-fold (0.15 log units), on the low side, within the range that was stated.
By their numbers in this assay, from the lowest: compounds 1 and 3 (each within the scatter of the next); then compound 2.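

In this assay the change from 4-hydroxy-2-methylphenyl to 4-ethylphenyl gives a 6.1-fold lower number from compound 2 to compound 3 (0.79 log units; beyond the scatter), so a second group without the hydroxyl stands apart from the group in compound 2. Methyl in place of hydrogen on the saturated chain carbon bound to an aromatic carbon gives a 1.7-fold higher number from compound 1 to compound 3 (0.22 log units; within the scatter), so 4-methylphenyl and 4-ethylphenyl cannot be told apart in this assay. Nothing measured here accounts for either step.

The compounds shown leave open how much of the step from compound 2 belongs to the hydroxyl and how much to the 2-methyl, which 4-hydroxyphenyl and 2-methylphenyl groups would separate. Going by these compounds, it also remains open whether a longer chain, such as propyl, would keep the number in the range of compound 1 and compound 3.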